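Carbamoyl in place of hydrogen on the distal phenyl

The compounds below may be only part of what the source reports. "The series", "measured", "known", "first", "only" and "open" are said of these compounds alone.

Compound 1 `O=C(O)CC/C=C\CO[C@H]1C(OCc2ccc(-c3ccccc3)cc2)CC[C@@H]1N1CCCCCC1` is one of three related acids with measured numbers in a functional assay on blood for antagonist activity at thromboxane A2 receptor (Homo sapiens); a higher number here means weaker binding, a lower number tighter binding. In this assay compound 1 gives 12.6 nM, the second highest of the three. Compound 2 `O=C(O)CC/C=C\CO[C@@H]1C(OCc2ccc(-c3ccccc3)cc2)CC[C@@H]1N1CCCCC1` gives 39.8 nM, a higher number beyond the scatter, while compound 3 `O=C(O)CC/C=C\CO[C@H]1[C@@H](OCc2ccc(-c3ccccc3CO)cc2)CC[C@@H]1N1CCCCCC1`, a relative carrying a hydroxymethyl substituent, gives 1.59 nM, a lower number that also lies beyond the scatter. Compound 4 `NC(=O)c1ccccc1-c1ccc(COC2CC[C@H](N3CCCCCC3)[C@H]2OC/C=C\CCC(=O)O)cc1` has not yet been measured. It differs from compound 1 in one place: carbamoyl in place of hydrogen on an aromatic carbon. Going by the values given here, no measured pair shows this exact change, so its size must be guessed. Compound 3 is the nearest pointer, and because it gives 1.59 nM a substituent added on this ring can go together with a markedly lower number. On that ground the step from compound 1 to compound 4 is expected to be a decrease of about a 3.9-fold lower number from compound 1 to compound 4 (0.60 log units; beyond the scatter). Compound 4 is therefore estimated at 3.2 nM, with a range from 1 nM to 12 nM.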

Compound 4, dissociation constant: 15.9 nM
Estimate against measurement, compound 4: 5.0-fold (0.70 log units) below; measured number outside the range, above it.
By their numbers in this assay, from the lowest: compound 3; then compounds 1 and 4 (each within the scatter of the next); then compound 2.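

In this assay, carbamoyl in place of hydrogen on an aromatic carbon, ortho to a large group, gives a 1.3-fold higher number from compound 1 to compound 4 (0.10 log units; within the scatter). Going by these compounds alone, this is the first direct reading of a single change at this position, as the earlier compounds offered no step between measured compounds that differ in one place. Here, phenyl to 2-carbamoylphenyl adds a group of 3 heavy atoms, with a hydrogen-bond donor and a hydrogen-bond acceptor, and the number stays within the scatter. No measurement is available that bears on the reason for this result.

From the compounds shown here alone, whether an amine, a carboxylic acid or a longer chain on the same aromatic carbon would also stay within the scatter remains open. The compounds shown also leave open how carbamoyl would read on another carbon of that ring.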